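The compounds below may be only part of what the source reports. "The series", "measured", "known", "first", "only" and "open" are said of these compounds alone.

Compound 1 `CCOC(=O)N1CCN(C(=O)c2nc(Nc3cc(C4CC4)[nH]n3)c3cc(Cl)ccc3n2)C[C@H]1C` and compound 2 `CC(OC(=O)N1CCN(C(=O)c2nc(Nc3cc(C4CC4)[nH]n3)c3cc(Cl)ccc3n2)C[C@H]1C)OC(=O)C(C)(C)C` share one core and differ in what hangs on the carbamate oxygen. In an assay for inhibition of serine/threonine-protein kinase PAK 4 (Homo sapiens), read by FRET and Z'-LYTE, with a stated time of 60 min, tested at 50 uM, in the presence of a further agent that is not named here (a lower number here means a weaker effect, a higher number a stronger effect of the compound at the concentration tested), compound 1 gives 93.4%, and compound 2 gives 65.3%. Among the compounds with values here, compound 2 stands lowest of the two numbers; the step of a number 28.1 percentage points lower from compound 1 to compound 2 (beyond the scatter) is the only measured step and shows that a larger group on that oxygen goes with a lower read-out. Compound 3 `CC(C)C(=O)OCOC(=O)N1CCN(C(=O)c2nc(Nc3cc(C4CC4)[nH]n3)c3cc(Cl)ccc3n2)C[C@H]1C` carries the change (((isopropylcarbonyl)oxy)methyl in place of 1-(((tert-butyl)carbonyl)oxy)ethyl on an oxygen next to a carbonyl group); this is a smaller group than the one it replaces, though still larger than the hydrogen of compound 1. Within the data shown here, the one bearing step, from compound 1 to compound 2, was modest and downward, so a partial reversal is expected here, with an upward step a number 10.7 percentage points higher from compound 2 to compound 3 (beyond the scatter) that may not clear the scatter. Compound 3 is therefore estimated at 76% in this assay, within a range of 58% to 92%.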

Compound 3, a percentage reported as inhibition, at one concentration (the size of the read-out at that concentration, not a potency) in the serine/threonine-protein kinase PAK 4 assay: 86.9%
Estimate against measurement, compound 3: 10.9 percentage points below; the measured number falls inside the stated range.
By their numbers in the serine/threonine-protein kinase PAK 4 assay, from the lowest: compound 2; then compounds 3 and 1 (each within the scatter of the next).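

In the serine/threonine-protein kinase PAK 4 assay, the step of a number 21.6 percentage points higher from compound 2 to compound 3 (beyond the scatter) shows that the read-out at this position responds to the group on the oxygen next to a carbonyl group, even when both groups carry an ester. The step of a number 6.5 percentage points lower from compound 1 to compound 3 (within the scatter) lies within the scatter, so the ((isopropylcarbonyl)oxy)methyl group of compound 3 does not carry the loss seen with the 1-(((tert-butyl)carbonyl)oxy)ethyl group of compound 2. In a physicochemical assay, read by HPLC, in phosphate buffer, with a stated time of 2 h, at pH 7.4 (a higher number here means that more of the compound is left, a lower number that less of the compound is left), compound 2 gives 90.5% and compound 3 gives 93.5% and the step of a number 3 percentage points higher from compound 2 to compound 3 (within the scatter) lies within the scatter, so this change leaves that read-out level.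

The methyl on the chain carbon and the tert-butyl change together here, and a ((tert-butyl)carbonyl)oxymethyl group would be needed to tell which of them goes with the lower number. No measurement shown here explains the difference between these groups.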